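From Pyrrolidin-1-yl to Azido on the Shared Core

The compounds below may be only part of what the source reports. "The series", "measured", "known", "first", "only" and "open" are said of these compounds alone.

Of the compounds shown here, three sharing one core have been measured in a functional assay on SW480 cells (Homo sapiens) for antiproliferative activity, read by MTT assay, with a stated time of 48 h; on this read-out lower numbers stand for stronger inhibition and higher numbers for weaker inhibition. There, compound 1 `COC/C1=C/C[C@](C)(CCC=C(C)C)/C=C/[C@@H](OC(=O)C=C(C)C)[C@](C)(O)/C=C/C1=O` gives 3850 nM, compound 2 `CC(C)=CCC[C@]1(C)/C=C/[C@@H](OC(=O)C=C(C)C)[C@](C)(O)/C=C/C(=O)/C(CCl)=C\C1` gives 390 nM, and compound 3 `CC(C)=CCC[C@]1(C)/C=C/[C@@H](OC(=O)C=C(C)C)[C@](C)(O)/C=C/C(=O)/C(CN2CCCC2)=C\C1` gives 310 nM. Compound 3 stands level with compound 2, since a 1.3-fold lower number from compound 2 to compound 3 (0.10 log units; within the scatter), and far from compound 1. The next structure, compound 4 `CC(C)=CCC[C@]1(C)/C=C/[C@@H](OC(=O)C=C(C)C)[C@](C)(O)/C=C/C(=O)/C(CN=[N+]=[N-])=C\C1`, carries azido in place of pyrrolidin-1-yl on a saturated chain carbon bound to a double-bonded ring carbon. Within the data shown here, all the measured steps bear on this change, as each falls at that same carbon. Chloro in place of methoxy gave a 9.9-fold lower number from compound 1 to compound 2 (0.99 log units; beyond the scatter), and pyrrolidin-1-yl in place of methoxy gave a 12-fold lower number from compound 1 to compound 3 (1.09 log units; beyond the scatter). The group there can therefore shift the number strongly, yet two unlike groups gave matching values. Azido is untested, so a modest step towards a higher number is expected in this assay, and a larger one towards compound 1 at 3850 nM cannot be excluded. The estimated value for compound 4 is 700 nM, with an expected range of 220 nM to 3000 nM. The expected step is a 2.3-fold higher number from compound 3 to compound 4 (0.35 log units; beyond the scatter).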

Compound 4, half-maximal inhibitory concentration: 4230 nM
For compound 4 the middle estimate is 6.0-fold (0.78 log units) below the measured one; measured number outside the range, above it.
By their numbers in this assay, from the lowest: compounds 3 and 2 (each within the scatter of the next); then compounds 1 and 4 (each within the scatter of the next).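

In this assay, azido does not join the two groups that gave the lower numbers on this saturated chain carbon: azido in place of pyrrolidin-1-yl gives (a 14-fold higher number from compound 3 to compound 4 (1.13 log units; beyond the scatter)) and azido in place of chloro gives (an 11-fold higher number from compound 2 to compound 4 (1.04 log units; beyond the scatter)). Azido in place of methoxy gives only (a 1.1-fold higher number from compound 1 to compound 4 (0.04 log units; within the scatter)), so the four groups now form two pairs, chloro with pyrrolidin-1-yl and methoxy with azido, and the higher numbers are no longer peculiar to methoxy. Nothing available here accounts for this division.

From the compounds shown here alone, whether another amine, such as piperidin-1-yl or dimethylamino, would stay with pyrrolidin-1-yl remains open, as does whether bromo or fluoro would stay with chloro. A hydroxyl group or a longer chain at this carbon could fall with either pair, and four groups cannot show what separates the pairs.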